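Swapping the group on the ring nitrogen of compound 2

This account rests on a few compounds, and the source may have more. Where it says the series, first, only, none or still open, it means among the compounds named here.

Compound 1 `COc1cc(C(=O)N2CCCC2)ccc1-c1ccnc2[nH]c(C3CCOCC3)cc12` and compound 2 `CC(=O)N1CCC(c2cc3c(-c4ccc(=O)n(C(C)C)c4)ccnc3[nH]2)CC1` have both been tested in a physicochemical assay for lipophilicity, using the shake flask method, measured as octanol-water partition, at pH 7.4; a higher number here means a more lipophilic compound, a lower number a more polar compound. Compound 1 gives 3, while compound 2 gives 2.1, the lower of the two numbers, a gap beyond the usual scatter. Compound 3 `CC(C)n1cc(-c2ccnc3[nH]c(C4CCN(CC(=O)N(C)C)CC4)cc23)ccc1=O` has not yet been measured; it differs from compound 2 in one place: (dimethylcarbamoyl)methyl in place of acetyl on an amine nitrogen in a ring. For the measured compounds named here, with no measured step of this kind at hand, the change is expected to shift this assay only slightly downward, close to the scatter, giving a number 0.30 log units lower from compound 2 to compound 3 (within the scatter). Compound 3 is therefore estimated at 1.8, within a range from 1 to 2.6.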

Compound 3, distribution coefficient: 1.9
Compound 3: the middle estimate sits 0.10 log units below what was measured; measured number inside the range.
By their numbers in this assay, from the lowest: compounds 3 and 2 (each within the scatter of the next); then compound 1.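

In this assay, putting (dimethylcarbamoyl)methyl in place of acetyl on the ring nitrogen gives a number 0.20 log units lower from compound 2 to compound 3 (within the scatter), so the two compounds cannot be told apart in this assay. This position therefore carries a group of six heavy atoms instead of three, both with one hydrogen-bond acceptor and no net charge, without a reading beyond the scatter. No measurement here offers an explanation for this result. Going by these compounds, whether an amine or a carboxylic acid on this nitrogen would stay as close remains open. So does whether a longer chain would.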